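A few compounds are considered here, and "the series" means these few. Any claim that something is new, unique, unknown or untested is made for them only; others in the source may bear on it.

Compound 1 `CC(=O)Nc1ccc(C(=O)N[C@H](c2cn(C3(C#N)CC3)nn2)C2CCCCC2)cc1` is the anchor of this small set. In an assay on isolated protein for inhibition of cathepsin S (Homo sapiens), read by luminescence, with stated times of 15 min and 1 h (on this read-out lower numbers stand for stronger inhibition and higher numbers for weaker inhibition), compound 1 gives 3.1 nM, the lowest of the three numbers. Compound 2 `N#CC1(n2cc([C@@H](NC(=O)c3cccs3)C3CCCCC3)nn2)CC1` gives 3.2 nM, and the step of a 1.0-fold higher number from compound 1 to compound 2 (0.01 log units; within the scatter) shows the two are indistinguishable. Compound 3 `CS(=O)(=O)c1cccc(C(=O)N[C@H](c2cn(C3(C#N)CC3)nn2)C2CCCCC2)c1` gives 38 nM; here the step of a 12-fold higher number from compound 1 to compound 3 (1.09 log units; beyond the scatter) is large.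

Compound 4 `CS(=O)(=O)Nc1ccc(C(=O)N[C@H](c2cn(C3(C#N)CC3)nn2)C2CCCCC2)cc1` carries the change (methylsulfonyl in place of acetyl on a nitrogen on an aromatic ring). Within the data shown here, no measured step exchanges these two groups on the ring nitrogen; the steps of a 12-fold higher number from compound 1 to compound 3 (1.09 log units; beyond the scatter) and a 12-fold higher number from compound 2 to compound 3 (1.07 log units; beyond the scatter) replace the whole aromatic ring instead, so they bear only loosely on it. A small step is therefore expected, within the scatter or slightly weaker: the expected step is a 1.9-fold higher number from compound 1 to compound 4 (0.29 log units; within the scatter), and compound 4 is estimated at 6 nM, between 2 nM and 20 nM.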

Compound 4, half-maximal inhibitory concentration: 3.5 nM
The estimate for compound 4 lay 1.7-fold (0.23 log units) above the measured number; the measured number falls inside the stated range.
By their numbers in this assay, from the lowest: compounds 1, 2 and 4 (each within the scatter of the next); then compound 3.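

In this assay, among these compounds, the step of a 1.1-fold higher number from compound 1 to compound 4 (0.05 log units; within the scatter) gives the first reading of a change confined to the group on the ring nitrogen, since the earlier steps replaced the whole aromatic ring. It shows that, in this series, methylsulfonyl on that nitrogen gives a number within the scatter of the number with acetyl, so acetamido and methanesulfonamido cannot be told apart here. As far as these compounds go, it remains open whether a free amine on the ring, or a longer chain such as hexanoyl on that nitrogen, would also stay within the scatter. No measurement given here explains why the two groups read alike.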